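Swapping Chloro for Methoxy on a Larger Analogue

The compounds below may be only part of what the source reports. "The series", "measured", "known", "first", "only" and "open" are said of these compounds alone.

Among the compounds with values here, compound 1 `CC(=O)OC[C@H]1O[C@H](OC[C@@H](Cn2cc(CN(c3nc(-c4ccc(Cl)cc4)no3)C3CCCCC3)nn2)OC(C)=O)C=C[C@@H]1OC(C)=O` is one of two compounds measured so far. In an ADME assay on RAW264.7 cells (Mus musculus) for cytotoxicity, read by MTT assay, with a stated time of 48 h (on this read-out higher numbers stand for lower toxicity in this test and lower numbers for higher toxicity in this test), compound 1 gives 35.5 ug/mL. Compound 2 `C#CCN(c1nc(-c2ccc(C)cc2)no1)C1CCCCC1` is a smaller relative that shares the same core; in this assay compound 2 gives 17.6 ug/mL. These two numbers lie within the usual scatter of each other, so neither compound can be set above the other on toxicity toward these cells. Within the data shown here, no step between two measured compounds that differ in a single place is available to guide expectations. Compound 3 `COc1ccc(-c2noc(N(Cc3cn(C[C@H](CO[C@@H]4C=C[C@H](OC(C)=O)[C@@H](COC(C)=O)O4)OC(C)=O)nn3)C3CCCCC3)n2)cc1` differs from compound 1 by methoxy in place of chloro on an aromatic carbon. With nothing measured to report on this kind of change, the step of a 1.1-fold lower number from compound 1 to compound 3 (0.05 log units; within the scatter) is expected to stay within the scatter, with no direction favoured. Compound 3 is therefore estimated at 32 ug/mL, with a range from 15 ug/mL to 65 ug/mL.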

Compound 3, half-maximal cytotoxic concentration: 86.3 ug/mL
Compound 3: middle estimate off by 2.7-fold (0.43 log units), on the low side; the measured number lies above the stated range.
By their numbers in this assay, from the lowest: compounds 2 and 1 (each within the scatter of the next); then compound 3.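

In this assay, within the data shown here, methoxy in place of chloro on the aromatic ring, para to a large group, gives a 2.4-fold higher number from compound 1 to compound 3 (0.39 log units; beyond the scatter), and this is the first change in a single place that can be read. The step lies beyond the usual scatter, so this position is not silent: with the rest of the large molecule unchanged, the group here alone moves the number toward lower toxicity in this test. No measurement shown gives a reason for this step.

From the compounds shown here alone, the position has so far been read with only these two groups, so it remains open how an amine, a carboxylic acid or a longer chain such as ethoxy would behave there. Going by these compounds, it is also open whether the same swap would give a similar step on a smaller relative that lacks the large sugar-bearing part.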